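Removing the 4-fluorobenzyl group from the shared core

The source may report more compounds than this note shows. Statements on the series, on what has been measured and on what is new or still open speak of the compounds shown alone.

Compound 2 `CCN1CCN(CCCn2cnc3c(N4CCN(C(=O)C5CCCC5)CC4)nc(NCc4ccc(F)cc4)nc32)CC1` sits at a limit in an assay on HEK293 cells for antagonist activity at Toll-like receptor 9 (Homo sapiens), read by spectrophotometry; a higher number here means a weaker inhibitor, a lower number a stronger inhibitor: compound 2 gives > 30000 nM, a limit and not a number. Compound 1 `CCN1CCN(CCCn2cnc3c(N4CCN(C(=O)C5CCCC5)CC4)nc(NCc4ccc(OC)cc4)nc32)CC1` is likewise at a limit, giving > 30000 nM in this assay. The step that the two limits leave unreadable from compound 1 to compound 2 stays unreadable because both values rest at the limit of > 30000 nM in this assay, at which 2 of the 2 values shown sit. Compound 3 `CCN1CCN(CCCn2cnc3c(N4CCN(C(=O)C5CCCC5)CC4)nc(N)nc32)CC1` carries hydrogen in place of 4-fluorobenzyl on a nitrogen on an aromatic ring. For the measured compounds named here, for compound 3 no measured step reads on this change, and the expected step that the limit leaves unreadable from compound 2 to compound 3 is therefore no shift beyond the scatter, with the limit most likely again. For compound 3 the estimate in this assay is 50000 nM, ranging from 15000 nM to 200000 nM.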

Compound 3, half-maximal inhibitory concentration: > 30000 nM
Compound 3: no number, only a limit; the forecaster's own chance of this, stated with the estimate: 85%; the middle value lies beyond the limit too.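

In this assay, for the compounds shown here, compound 3 gives > 30000 nM as a limit and not a number, so no step from compound 1 or compound 2 to compound 3 can be read: (the limit of > 30000 nM in this assay, at which 3 of the 3 values shown sit). The compounds shown leave open which change on the shared core would give a measurable inhibitory value.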